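A few compounds are considered here, and "the series" means these few. Any claim that something is new, unique, unknown or untested is made for them only; others in the source may bear on it.

Two members of the series have been run in an assay on HEK293 cells for negative allosteric modulation of metabotropic glutamate receptor 5 (Homo sapiens), read by FLIPR, with a stated time of 1 h; on this read-out higher numbers stand for weaker inhibition and lower numbers for stronger inhibition. Compound 1 `C(#Cc1nc2c(s1)CN(C1CCCCC1)CC2)c1ccccc1` carries a cyclohexyl on the amine nitrogen in a ring; in this assay compound 1 returns only the limit > 10000 nM. Compound 2 `COC1CC(C(=O)N2CCc3nc(C#Cc4ccccc4)sc3C2)C1` has the (3-methoxycyclobutyl)carbonyl in place of cyclohexyl on that nitrogen; in this assay compound 2 likewise returns only the limit > 10000 nM. Among the measured compounds shown here, the one step measured so far, a step that the two limits leave unreadable from compound 1 to compound 2, is thus unreadable, as the limit of > 10000 nM in this assay, at which 2 of the 2 values shown sit, shows. Compound 2 stands at the limit, with nothing to separate it from compound 1.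

The next compound, compound 3 `N#Cc1cccc(C(=O)N2CCc3nc(C#Cc4ccccc4)sc3C2)c1`, differs from compound 2 by 3-cyanophenyl in place of 3-methoxycyclobutyl on a carbonyl carbon. For the measured compounds named here, no measured step bears on this change: the single step, a step that the two limits leave unreadable from compound 1 to compound 2, concerns the amine substituent and has no readable size, so neither direction nor magnitude can be drawn from it. With both measured compounds sitting at the limit of > 10000 nM in this assay, at which 2 of the 2 values shown sit, there is no ground for expecting the amide series to move into readable inhibition. The step of an at least 1.4-fold lower number from compound 2 to compound 3 (0.15 log units; that floor lies within the scatter) is expected to be none beyond the scatter. Compound 3 is estimated at 7000 nM, within 800 nM to 30000 nM, with a limit the likeliest report.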

Compound 3, half-maximal inhibitory concentration: > 10000 nM
Compound 3: no number, only a limit; the forecaster's own chance of this, stated with the estimate: 55%; middle value at least 1.4-fold (0.15 log units) away from the limit.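

Compound 2 and compound 3 both return only a limit of the assay, and no size can be read for the step between them: the limit of > 10000 nM in this assay, at which 3 of the 3 values shown sit.

The compounds shown leave open whether any group on the carbonyl carbon, or on the amine nitrogen in a ring, gives a readable inhibition at all.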